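The source may hold more compounds than are shown below. What is called first, only, known or untested is meant among the compounds shown, and "the series" means these compounds.

Measured so far in a functional assay on MDA-MB-231 cells (Homo sapiens) for inhibition, read by MTT assay, with a stated time of 48 h; a higher number here means a weaker inhibitor, a lower number a stronger inhibitor:
compound 1 `COc1cc(-c2cc(-c3ccc(Br)cc3)nc(-c3ccccc3)n2)cc(OC)c1OC`: > 25000 nM, a limit of the assay.
compound 2 `COc1cc(-c2cc(-c3ccc(O)cc3)nc(-c3ccccc3)n2)cc(OC)c1OC`: 1600 nM.

Compound 1 stands only at a limit in this assay; its value of > 25000 nM is the assay limit of > 25000 nM in this assay, at which 1 of the 2 values shown sits, and not a number. Compound 2 gives 1600 nM. Among the compounds with values here, the single measured step, an at least 15-fold lower number from compound 1 to compound 2 (1.19 log units; beyond the scatter), is the only reference and lies beyond the scatter. Compound 3 `COc1cc(-c2cc(-c3cccs3)nc(-c3ccccc3)n2)cc(OC)c1OC` differs from compound 1 at the same place: thiophen-2-yl in place of 4-bromophenyl on an aromatic carbon. Within the data shown here, the measured step concerns hydroxy in place of bromo, not thiophen-2-yl in place of 4-bromophenyl, so it shows only that a change at this place can move the number far. A step toward a lower number is expected, smaller than the measured one. For compound 3 the estimate is 6000 nM, with a range of 1200 nM to 25000 nM. The step expected is an at least 4.1-fold lower number from compound 1 to compound 3 (0.61 log units; beyond the scatter).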

Compound 3, half-maximal inhibitory concentration: 5110 nM
Compound 3: middle estimate off by 1.2-fold (0.07 log units), on the high side; the range from low to high includes it.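

Compound 1 stands at a limit of the assay and not at a number: the limit of > 25000 nM in this assay, at which 1 of the 3 values shown sits.

In this assay, this place does not need a hydroxy group to give a measurable value: a five-membered aromatic ring with sulfur as its hetero atom and no hydrogen-bond donor also moves the number down (an at least 4.8-fold lower number from compound 1 to compound 3 (0.68 log units; beyond the scatter)). The two replacements are not equal, however, and thiophen-2-yl falls short of 4-hydroxyphenyl by a margin beyond the scatter (a 3.2-fold higher number from compound 2 to compound 3 (0.50 log units; beyond the scatter)).

The compounds shown do not separate the part played by the sulfur from that of the smaller ring, as no pair changes only one of these. From the compounds shown here alone, it also remains open how an amine or a carboxylic acid on the phenyl ring at this place, or a furan-2-yl group in place of thiophen-2-yl, would compare with 4-hydroxyphenyl.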